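Oxetan-3-yl for oxolan-3-yl on the core ring nitrogen

The source may report more compounds than this note shows. Statements on the series, on what has been measured and on what is new or still open speak of the compounds shown alone.

Measured so far in a physicochemical assay for lipophilicity; on this read-out lower numbers stand for lower lipophilicity and higher numbers for higher lipophilicity:
compound 1 `CC[C@@H]1C(=O)N(C)c2cnc(-n3ccnc3-c3ccc(F)cc3)nc2N1[C@H]1CCOC1`: 2
compound 2 `CC[C@@H]1C(=O)N(C)c2cnc(-n3ccnc3-c3ccccc3)nc2N1[C@H]1CCOC1`: 1.9
compound 3 `CCC1C(=O)N(C)c2cnc(-n3ccnc3-c3ccccc3)nc2N1c1ccccc1`: 3.3
compound 4 `CC[C@@H]1C(=O)N(C)c2cnc(-n3ccnc3-c3ccc(F)cc3)nc2N1C1COC1`: not yet measured

Compound 1 stands second highest of the three numbers in this assay. Among the compounds with values here, its nearest neighbour is compound 2, at 1.9, a gap within the scatter; the one step that joins two measured compounds at a single place, a number 0.10 log units lower from compound 1 to compound 2 (within the scatter), is this one. The furthest is compound 3, at 3.3, a gap beyond the scatter, though compound 3 differs from compound 1 in more than one place, so only the two values themselves can be read.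

The step to compound 4 is oxetan-3-yl in place of oxolan-3-yl on a nitrogen on an aromatic ring in a ring. Within the data shown here, no measured step touches this position; the one measured step lies on the aryl ring and is within the scatter, so it gives no direct guide. The change shortens the group that sits on the ring nitrogen by one carbon, which is the only thing the counted difference shows. On that basis a modest decrease in this assay is expected, a number 0.50 log units lower from compound 1 to compound 4 (beyond the scatter), not a large one. Compound 4 is therefore estimated at 1.5, with a range of 1 to 2.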

Compound 4, partition coefficient: 1.6
Estimate against measurement, compound 4: 0.10 log units below, and the stated range covers the measured number.
By their numbers in this assay, from the lowest: compounds 4, 2 and 1 (each within the scatter of the next, the first and the last beyond it); then compound 3.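

Oxetan-3-yl in place of oxolan-3-yl on the nitrogen gives the first measured step at this position in this assay, and it is a number 0.40 log units lower from compound 1 to compound 4 (beyond the scatter) and so lies beyond the scatter. The earlier single-place step, a number 0.10 log units lower from compound 1 to compound 2 (within the scatter) and so within the scatter, was hydrogen in place of fluoro on an aromatic carbon and said nothing about this nitrogen. The step swaps a five-membered ring for a four-membered one and also removes the defined stereocentre of the oxolan-3-yl group, so the compounds shown cannot separate the two changes, and no measurement bears on the cause of the step.

On these data alone, whether the step carries over to the hydrogen analogue, compound 2, remains open. So does the read-out with azetidin-3-yl, cyclobutyl or an open chain such as 2-methoxyethyl on this nitrogen.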